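The source may hold more compounds than are shown below. What is called first, only, known or untested is meant among the compounds shown, and "the series" means these compounds.

Measured compounds:
compound 1, `COc1cc2ncnc(Nc3ccc(NC(=O)c4cccc(C)c4)cc3)c2cc1OC`, 13000 nM
compound 2, `CCc1ccc(C(=O)Nc2ccc(Nc3ncnc4cc(OC)c(OC)cc34)cc2)cc1`, 65000 nM
compound 3, `COc1cc2ncnc(Nc3ccc(NC(=O)c4c(F)cccc4F)cc3)c2cc1OC`, 24000 nM

All three were tested in a functional assay on MCF7 cells (Homo sapiens) for inhibition, read by MTT assay; a higher number here means a weaker inhibitor, a lower number a stronger inhibitor. Among them, compound 2 gives the highest number, with a 2.7-fold lower number from compound 2 to compound 3 (0.43 log units; beyond the scatter) and, in the other direction, a 5.0-fold higher number from compound 1 to compound 2 (0.70 log units; beyond the scatter) setting it apart from both neighbours. The unmeasured compound 4, `COc1cc2ncnc(Nc3ccc(NC(=O)c4cc(F)ccc4Br)cc3)c2cc1OC`, differs from compound 2 only on the carbonyl carbon: 2-bromo-5-fluorophenyl in place of 4-ethylphenyl on a carbonyl carbon. Among the measured compounds shown here, the one measured step that bears most directly on this change is the one from compound 2 to compound 3, where a halogenated phenyl replaced the same 4-ethylphenyl and the number fell by a 2.7-fold lower number from compound 2 to compound 3 (0.43 log units; beyond the scatter), a modest shift beyond the scatter. The step from compound 1 to compound 2, a 5.0-fold higher number from compound 1 to compound 2 (0.70 log units; beyond the scatter), also shows 4-ethylphenyl to be the weakest of the three groups here. Compound 4 is therefore expected to come in with a modestly lower number than compound 2, a 3.0-fold lower number from compound 2 to compound 4 (0.47 log units; beyond the scatter), since both precedents point that way. The estimate for compound 4 in this assay is 22000 nM, with a range from 8000 nM to 55000 nM.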

Compound 4, half-maximal inhibitory concentration: 26000 nM
Compound 4: middle estimate off by 1.2-fold (0.07 log units), on the low side; measured number inside the range.
By their numbers in this assay, from the lowest: compounds 1, 3 and 4 (each within the scatter of the next); then compound 2.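

In this assay, a second halogenated phenyl also separates from 4-ethylphenyl on the carbonyl carbon (a 2.5-fold lower number from compound 2 to compound 4 (0.40 log units; beyond the scatter)), so the earlier drop with 2,6-difluorophenyl is not a lone case. The 2-bromo-5-fluorophenyl group does not separate from the other two groups (a 1.1-fold higher number from compound 3 to compound 4 (0.03 log units; within the scatter); a 2.0-fold higher number from compound 1 to compound 4 (0.30 log units; within the scatter)), which leaves compound 1, compound 3 and compound 4 level, with only compound 2 apart. Nothing available explains why the 4-ethylphenyl compound stands apart from the other three.

Going by these compounds, all four compounds carry a substituted phenyl on the carbonyl carbon, so it remains open how a carboxylic acid, an amine or a longer chain on that phenyl would read. The compounds also leave the contributions of the bromine and the fluorine in 2-bromo-5-fluorophenyl unseparated.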